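The source may hold more compounds than are shown below. What is called first, only, known or untested is meant among the compounds shown, and "the series" means these compounds.

Measured in a functional assay on MDA-MB-231 cells (Homo sapiens) for antiproliferative activity, read by MTT assay, with a stated time of 48 h; on this read-out higher numbers stand for weaker inhibition and lower numbers for stronger inhibition:
- compound 1 `O=C(/C=C/c1ccccc1)Nc1cc2c(Nc3ccc(F)c(Cl)c3)ncnc2s1`: 7600 nM
- compound 2 `N#Cc1cccc(Nc2ncnc3cc(NC(=O)/C=C/c4ccccc4)sc23)c1`: 1040 nM
- compound 3 `COc1ccc(/C=C/C(=O)Nc2cc3c(Nc4cc(Cl)cc(Cl)c4)ncnc3s2)cc1`: 1970 nM

Compound 2, at 1040 nM, sits within the scatter of compound 3, and its number lies beyond the scatter below that of compound 1. Compound 4 `O=C(/C=C/c1ccccc1)Nc1cc2ncnc(Nc3ccc(Cl)c(Cl)c3)c2s1`, not yet measured, carries 3,4-dichlorophenyl in place of 3-cyanophenyl on a nitrogen on an aromatic ring. Among the measured compounds shown here, no measured pair shows this change alone. Compound 3, with chlorine on that phenyl ring, gives 1970 nM, and compound 1, also chlorinated there, gives 7600 nM, though both differ from compound 2 elsewhere too. A modest move toward weaker inhibition is therefore expected, an estimated 2.4-fold higher number from compound 2 to compound 4 (0.38 log units; beyond the scatter). For compound 4 the estimated value is 2500 nM, with an expected range from 800 nM to 8000 nM.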

Compound 4, half-maximal inhibitory concentration: 2410 nM
The estimate for compound 4 lay 1.0-fold (0.02 log units) above the measured number, and the stated range covers the measured number.
By their numbers in this assay, from the lowest: compounds 2, 3 and 4 (each within the scatter of the next, the first and the last beyond it); then compound 1.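

Replacing 3-cyanophenyl with 3,4-dichlorophenyl on a nitrogen on an aromatic ring gives a 2.3-fold higher number from compound 2 to compound 4 (0.36 log units; beyond the scatter) in this assay. Among the compounds shown here, this is the first reading of this position with the rest of the molecule held constant, and it shows that the change costs only a modest loss of inhibition. No measurement here accounts for the shift.

The compounds shown leave open whether the step follows from losing the nitrile or from gaining the chlorines. They also leave open how a phenyl ring carrying an amine or a carboxylic acid would read at this position.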